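The source may report more compounds than this note shows. Statements on the series, on what has been measured and on what is new or still open speak of the compounds shown alone.

Of the compounds shown here, three built on one shared core have been tested in a functional assay on SMMC-7721 cells (Homo sapiens) for cytotoxicity, read by MTT assay, with a stated time of 4 days; on this read-out higher numbers stand for weaker inhibition and lower numbers for stronger inhibition. Compound 3 `C=C1C[C@]23C[C@@]1(O)CC[C@@H]2c1cccc(C)c1[C@@H]3Cn1cc(-c2ccc(F)cc2)nn1` gives > 20000 nM, which is a limit of the assay rather than a number. Compound 2 `C=C1C[C@]23C[C@@]1(O)CC[C@@H]2c1cccc(C)c1[C@@H]3Cn1cc(-c2ccccc2)nn1` likewise gives only the limit > 20000 nM. Compound 1 `C=C1C[C@]23C[C@@]1(O)CC[C@H]2c1cc(Br)c(O)c(C)c1[C@@H]3Cn1cc(-c2ccc(C)cc2)nn1` also sits at the limit, > 20000 nM. Within the data shown here, the only measured single change, a step that the two limits leave unreadable from compound 2 to compound 3, therefore cannot be sized, and the limit of > 20000 nM in this assay, at which 3 of the 3 values shown sit, is the whole of the evidence. Compound 4 `C=C1C[C@]23C[C@@]1(O)CC[C@@H]2c1cccc(C)c1[C@@H]3Cn1cc(-c2ccccn2)nn1` differs from compound 3 by pyridin-2-yl in place of 4-fluorophenyl on an aromatic carbon. Among the measured compounds shown here, no measured step bears on this change, so neither a direction nor a size beyond the scatter can be read from the data. The expected step is a step that the limit leaves unreadable from compound 3 to compound 4. Compound 4 is estimated at 30000 nM, with a range from 8000 nM to 100000 nM.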

Compound 4, half-maximal inhibitory concentration: > 20000 nM
Compound 4 gave a limit, no number; the forecaster's own chance of this, stated with the estimate: 85%; the middle value does not contradict the limit.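

Compound 4 gives > 20000 nM as a limit and not a number, so its steps from compound 2 and compound 3 cannot be read. The compounds shown leave open whether any change to the shared core would give a readable number in this assay at all.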